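A few compounds are considered here, and "the series" means these few. Any claim that something is new, unique, unknown or untested is made for them only; others in the source may bear on it.

Measured in an assay on HEK293 cells for displacement of a labelled ligand from growth hormone secretagogue receptor type 1 (Homo sapiens), with a stated time of 60 min; on this read-out lower numbers stand for stronger inhibition and higher numbers for weaker inhibition:

Compound 1 `Cc1ccccc1-c1nc2cn(-c3cccc(C#N)c3)nc2c(=O)n1CC1CCCN(C(C)C)C1`: 32 nM
Compound 2 `COc1cccc(-n2cc3nc(-c4cccnc4C)n(C[C@H]4CCCN(CC5CCC5)C4)c(=O)c3n2)c1`: 1.6 nM
Compound 3 `COc1cccc(-n2cc3nc(-c4ccccc4C)n(CC4CCCN(C(C)C)C4)c(=O)c3n2)c1`: 1.8 nM

Among these three, compound 2 gives the lowest number, though compound 3 sits within the usual scatter of it, so the two cannot be ranked; only compound 1 stands clearly apart, beyond the scatter. Going by the values given here, the one measured single-point step, an 18-fold lower number from compound 1 to compound 3 (1.25 log units; beyond the scatter), concerns a group on an aromatic ring, not the chain on the ring amine, so it says nothing direct about the change considered here. Compounds 2 and 3 differ at the ring amine as well as at an aromatic ring, so their two values cannot be split between those two places.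

Compound 4 `CCO[C@H](C)CN1CCC[C@H](Cn2c(-c3cccnc3C)nc3cn(-c4cccc(OC)c4)nc3c2=O)C1` is compound 2 with 1-ethoxyethyl in place of cyclobutyl on a saturated chain carbon bound to an amine nitrogen in a ring. Among the compounds with values here, no measured step isolates this position, so the expectation leans on the nearness of compounds 2 and 3, which carry unlike groups there yet give similar numbers: the expected step is a 1.3-fold higher number from compound 2 to compound 4 (0.10 log units; within the scatter), none beyond the scatter. Compound 4 is therefore estimated at 2 nM, between 0.7 nM and 6 nM.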

Compound 4, half-maximal inhibitory concentration: 40 nM
Compound 4: the middle estimate sits 20-fold (1.30 log units) below what was measured; the measured number lies above the stated range.
By their numbers in this assay, from the lowest: compounds 2 and 3 (each within the scatter of the next); then compounds 1 and 4 (each within the scatter of the next).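

Replacing cyclobutyl with 1-ethoxyethyl on a saturated chain carbon bound to an amine nitrogen in a ring gives a 25-fold higher number from compound 2 to compound 4 (1.40 log units; beyond the scatter), so the group at this position clearly matters in this assay. This single change removes a four-membered carbon ring and adds an open chain with an oxygen, a hydrogen-bond acceptor and a defined stereocentre, so several differences arrive together. No measurement shown here explains the rise in the number.

The compounds shown leave open which of those differences matters, and whether the other arrangement at the new stereocentre would give a similar number. An open butyl chain without oxygen and an oxetanyl ring, which keeps a ring while holding an oxygen, would help to separate the loss of the ring from the arrival of the oxygen.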